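Exchanging One Ring Group: Compound 3 to Compound 4

This account rests on a few compounds, and the source may have more. Where it says the series, first, only, none or still open, it means among the compounds named here.

Measured in a functional assay with Oryctolagus cuniculus as the target; on this read-out lower numbers stand for stronger inhibition and higher numbers for weaker inhibition:
- Compound 1 `COc1ccc(-c2nc(CNC(=O)N3CCOCC3)sc2-c2ccc(OC)cc2)cc1`: 660 nM
- Compound 2 `COc1ccc(-c2nc(C(N)=O)sc2-c2ccc(OC)cc2)cc1`: > 1000 nM
- Compound 3 `COc1ccc(-c2nc(C3=NNC(=O)CC3)sc2-c2ccc(OC)cc2)cc1`: > 1000 nM

Compound 1 is the only one of the three with a true number. For compound 2, the entry of > 1000 nM is a limit. For compound 3, the entry of > 1000 nM is likewise a limit, and it is the limit of > 1000 nM in this assay, at which 2 of the 3 values shown sit.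

The next structure is compound 4 `COc1ccc(-c2nc(C3=CCN(C)CC3)sc2-c2ccc(OC)cc2)cc1`, and the change is a group of 7 heavy atoms (6 carbon, 1 nitrogen; one six-membered non-aromatic ring with 1 hetero atom) in place of a group of 7 heavy atoms (4 carbon, 2 nitrogen, 1 oxygen; one six-membered non-aromatic ring with 2 hetero atoms), on an aromatic carbon. For the measured compounds named here, no measured step makes this exchange, so the evidence is indirect. The closest steps also alter the group on an aromatic carbon. They show an at least 1.5-fold higher number from compound 1 to compound 2 (0.18 log units; that floor lies within the scatter) and an at least 1.5-fold higher number from compound 1 to compound 3 (0.18 log units; that floor lies within the scatter). Between the two limits there is a step that the two limits leave unreadable from compound 2 to compound 3.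

None of these steps gives a size or a direction for the new group, so no change beyond the scatter is expected in this assay. Going by the values given here, the one true number is that of compound 1, at 660 nM. A reading close to the limit is plausible, and another limit would not be surprising. The expected step is a step that the limit leaves unreadable from compound 3 to compound 4. For compound 4 the estimated value is 1300 nM, with an expected range from 350 nM to 5000 nM.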

Compound 4, half-maximal inhibitory concentration: < 10 nM
Compound 4: only a limit was reported; the forecaster's own chance of this, stated with the estimate: 60%; middle value at least 130-fold (2.11 log units) from the limit.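

In this assay, compound 4 carries a limit and not a true number: the limit of < 10 nM in this assay, at which 1 of the 4 values shown sits. On an aromatic carbon of the five-membered aromatic ring with 1 nitrogen and 1 sulfur, the entering group, with its six-membered non-aromatic ring with 1 hetero atom, gives an at least 100-fold lower number from compound 3 to compound 4 (2.00 log units; beyond the scatter), an at least 100-fold lower number from compound 2 to compound 4 (2.00 log units; beyond the scatter) and an at least 66-fold lower number from compound 1 to compound 4 (1.81 log units; beyond the scatter). For the compounds shown here, the earlier steps at this place were either unreadable or had floors within the scatter, so this is the first sign that the place can carry a large change, and compound 3 shows that a six-membered non-aromatic ring of the same heavy-atom count does not by itself give it.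

The compounds shown leave open which difference between the leaving and the entering group goes with the step, as the carbonyl, the second ring nitrogen, the hydrogen-bond donor and one double bond all change together with the methyl on the ring nitrogen. They also leave open how far the true value of compound 4 lies past its limit, and how a saturated piperidine ring, an open-chain amine or a carboxylic acid would read at this carbon.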